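Working notes: from compound 3 to compound 4, microsomal half-life

The source may hold more compounds than are shown below. What is called first, only, known or untested is meant among the compounds shown, and "the series" means these compounds.

The shared core carries two ethyl groups and a 2,4-dichlorophenyl group, and the series is read in an in vitro ADME assay on microsomes (Rattus norvegicus) for metabolic stability; on this read-out higher numbers stand for a longer-lived compound and lower numbers for a shorter-lived compound. Compound 1 `CCc1nc(-c2ccc(Cl)cc2Cl)c(CC)nc1SC(C)CC` gives 0.0683 h, and compound 2 `CCCN(CC1CC1)c1nc(CC)c(-c2ccc(Cl)cc2Cl)nc1CC` gives 0.07 h; the pair lies within the scatter, as a 1.0-fold higher number from compound 1 to compound 2 (0.01 log units; within the scatter) shows. Compound 3 `CCc1nc(N(CC2CC2)CC2CC2)c(CC)nc1-c1ccc(Cl)cc1Cl` reaches only a limit of this assay, < 0.0167 h. That limit is the one noted as the limit of < 0.0167 h in this assay, at which 1 of the 3 values shown sits. Measured against the two numbered compounds, the steps are an at least 4.0-fold lower number from compound 1 to compound 3 (0.61 log units; beyond the scatter) and an at least 4.1-fold lower number from compound 2 to compound 3 (0.62 log units; beyond the scatter), so compound 3 stands as the shortest-lived member of the set, known only as a limit rather than a number.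

Compound 4 `CCc1nc(-c2ccc(Cl)cc2Cl)c(CC)nc1NC(C1CC1)C1CC1` has not yet been run in this assay. It differs from compound 3 by (dicyclopropylmethyl)amino in place of bis(cyclopropylmethyl)amino on an aromatic carbon. Going by the values given here, no measured step covers this exchange itself; the only steps that bear on compound 3 are the two that end at its limit, both beyond the scatter. With the starting point a limit, the direction of the step cannot be fixed from the data, and a number close to that limit is the working expectation.

Compound 4 is therefore expected to give about 0.02 h, within a range from 0.008 h to 0.06 h. The estimated step is an at least 1.1-fold higher number from compound 3 to compound 4 (0.07 log units; that floor lies within the scatter), and a repeat limit is considered nearly as likely as a number.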

Compound 4, half-life: 0.0417 h
Compound 4: the middle estimate sits 2.1-fold (0.32 log units) below what was measured, and the stated range covers the measured number.
By their numbers in this assay, from the lowest: compounds 4, 1 and 2 (each within the scatter of the next). At a limit, below all of these: compound 3.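

At this position, on an aromatic carbon next to the ring nitrogen, (dicyclopropylmethyl)amino in place of bis(cyclopropylmethyl)amino lifts the read-out in this assay off the limit, with an at least 2.4-fold higher number from compound 3 to compound 4 (0.39 log units; beyond the scatter); both groups hold 2 three-membered rings, so among these two compounds the presence of the rings alone does not place a compound at the limit, and the exchange also brings 1 hydrogen-bond donor where there were 0. The other two groups at this place do not separate from the new one, as a 1.7-fold lower number from compound 2 to compound 4 (0.22 log units; within the scatter) and a 1.6-fold lower number from compound 1 to compound 4 (0.21 log units; within the scatter) both show, so a sulfanyl link, a fully substituted amino group and an amino group that keeps its hydrogen all read alike here. Compound 3 thus remains the only compound apart from the others, and its entry is a limit and not a number: the limit of < 0.0167 h in this assay, at which 1 of the 4 values shown sits.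

The compounds shown do not separate the hydrogen-bond donor from the change in how the two cyclopropyl rings are attached, a question that the N-methyl form of (dicyclopropylmethyl)amino would bear on. Also open, as far as these compounds go, is whether an ether oxygen in place of the amino nitrogen, or a hydroxyl on the side chain, would move the half-life beyond the narrow band held by compounds 1, 2 and 4.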